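The source may report more compounds than this note shows. Statements on the series, on what has been measured and on what is new or still open speak of the compounds shown alone.

Series notes. Compound 1 `O=C1N=C(O)S/C1=C\c1ccc(OCCc2ccsc2)cc1` gives 60 nM in an assay for inhibition of 15-hydroxyprostaglandin dehydrogenase [NAD(+)] (Homo sapiens), read by fluorescence and spectrophotometry; a higher number here means a weaker inhibitor, a lower number a stronger inhibitor. For the measured compounds named here, compound 2 `O=C1N=C(O)S/C1=C\c1ccc(OCc2cccs2)cc1` gives 287 nM in this assay, the higher of the two numbers recorded; the one measured step is a 4.8-fold higher number from compound 1 to compound 2 (0.68 log units; beyond the scatter). Compound 3 `O=C1N=C(O)S/C1=C\c1ccc(OCc2ccsc2)cc1` differs from compound 2 by thiophen-3-yl in place of thiophen-2-yl on a saturated chain carbon bound to an oxygen on an aromatic ring. That measured step bears on this change only in part, since it alters the thiophene attachment and the chain length together, so its size marks the most the attachment alone is likely to account for. A step of a 1.9-fold lower number from compound 2 to compound 3 (0.28 log units; within the scatter) is expected, with no change beyond the scatter remaining possible. Compound 3 is estimated at 150 nM, between 60 nM and 400 nM.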

Compound 3, half-maximal inhibitory concentration: 429 nM
Compound 3: middle estimate off by 2.9-fold (0.46 log units), on the low side; the measured number lies above the stated range.
By their numbers in this assay, from the lowest: compound 1; then compounds 2 and 3 (each within the scatter of the next).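

In this assay, thiophen-3-yl in place of thiophen-2-yl on this saturated chain carbon gives a 1.5-fold higher number from compound 2 to compound 3 (0.17 log units; within the scatter), so the attachment point of the thiophene does not separate these two compounds. With the attachment held as thiophen-3-yl, thiophen-3-yl in place of (thiophen-3-yl)methyl gives a 7.2-fold higher number from compound 1 to compound 3 (0.85 log units; beyond the scatter), which ties the earlier gap to the chain rather than to the attachment. No measurement on hand accounts for either step.

Open, on these data alone, is whether (thiophen-2-yl)methyl in place of (thiophen-3-yl)methyl on the chain of compound 1 would also leave the number within the scatter. Also open, as far as these compounds go, is whether a longer chain or a phenyl in place of the thiophene would hold the number of compound 1.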